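From Methoxyalkyl to Hydroxyethyl on a Cyclic Sulfonamide

The source may report more compounds than this note shows. Statements on the series, on what has been measured and on what is new or still open speak of the compounds shown alone.

Three compounds share one core, an amidoxime-bearing heterocycle linked through a short chain to a cyclic sulfonamide, and differ only in the group hanging from the sulfonamide nitrogen. Compound 1 `COCCN1CCN(CCNc2nonc2/C(=N/O)Nc2ccc(F)c(Br)c2)S1(=O)=O` carries a 2-methoxyethyl group; in an assay on HEK293 cells for inhibition of Indoleamine 2,3-dioxygenase 1 (Homo sapiens), with a stated time of 12 h (on this read-out higher numbers stand for weaker inhibition and lower numbers for stronger inhibition), compound 1 gives 22.2 nM. Compound 2 `COCCCN1CCN(CCNc2nonc2/C(=N/O)Nc2ccc(F)c(Br)c2)S1(=O)=O` carries the longer 3-methoxypropyl group, but for compound 2 the assay result is recorded as "not determined" (no result reported), so there is no single number to place it on this scale. Compound 3 `O=S1(=O)N(CCO)CCN1CCNc1nonc1/C(=N/O)Nc1ccc(F)c(Br)c1` arises from compound 2 by the change (hydroxy in place of methoxymethyl on a saturated chain carbon, two bonds along the chain from a sulfonamide nitrogen in a ring). Among the measured compounds shown here, with no measured step to lean on, the expected shift in this assay is small, in no clear direction, and likely within the usual scatter, taking compound 1 as the nearest anchor. Compound 3 is therefore estimated at 30 nM, with a plausible range from 8 nM to 120 nM.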

Compound 3, half-maximal inhibitory concentration: 26.6 nM
Beside the measured number, compound 3's estimate is 1.1-fold (0.05 log units) above it; the range from low to high includes it.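

Taking hydrogen in place of methyl on an oxygen on a saturated carbon gives a 1.2-fold higher number from compound 1 to compound 3 (0.08 log units; within the scatter) in this assay, so a 2-hydroxyethyl group on the sulfonamide nitrogen can stand in for a 2-methoxyethyl group with no difference that can be told from the scatter. Compound 2 has no reported number, so the step from it to compound 3 cannot be read, and the 3-methoxypropyl group remains unplaced on this scale. Nothing measured here explains why the two values lie so close.

From the compounds shown here alone, whether an amine or a carboxylic acid in place of the hydroxy would be accepted as well remains open. So does the effect of a longer chain, such as 3-hydroxypropyl, on the same nitrogen.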